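Swapping bromine for chlorine on two related indole-bearing cores

The source may hold more compounds than are shown below. What is called first, only, known or untested is meant among the compounds shown, and "the series" means these compounds.

Measured compounds:
- compound 1, `COC(=O)[C@@]1(C)CCC=C2[C@@H]1CC[C@@H](C)[C@]2(C)Cc1c[nH]c2ccc(Br)cc12`: 16000 nM
- compound 2, `COC(=O)[C@@]1(C)CCC=C2[C@@H]1CC[C@@H](C)[C@]2(C)Cc1c[nH]c2ccc(Cl)cc12`: 17000 nM
- compound 3, `COC(=O)[C@@]1(C)CC[C@@H]2C3=C1CC[C@@H](C)[C@]3(C)C[C@@H]1c3cccc(Br)c3N[C@H]21`: 37000 nM

All three were tested in a functional assay on T47D cells (Homo sapiens) for inhibition, read by sulforhodamine B assay, with a stated time of 48 h; on this read-out lower numbers stand for stronger inhibition of growth and higher numbers for weaker inhibition of growth. Compound 1 and compound 2 share a core and differ only by chloro in place of bromo on an aromatic carbon. The step of a 1.1-fold higher number from compound 1 to compound 2 (0.03 log units; within the scatter) shows that this exchange left the growth inhibition essentially unchanged. Compound 3 is built from the same atoms as compound 1, joined differently; how the two cores differ is not broken down here. In this assay compound 3 gives the highest of the three numbers, and its nearest neighbour is compound 2.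

Compound 4, `COC(=O)[C@@]1(C)CC[C@@H]2C3=C1CC[C@@H](C)[C@]3(C)C[C@@H]1c3cccc(Cl)c3N[C@H]21`, has not yet been measured. It is related to compound 3 by chloro in place of bromo on an aromatic carbon, which is the same kind of change as that from compound 1 to compound 2, but not the same: in compound 1 the exchanged halogen sits on a ring that is part of a fused or bridged system of two rings, meta to a fused ring and para to a fused ring, whereas in compound 3 it sits on a ring within a fused or bridged system of five rings, ortho to a fused ring and meta to a fused ring.

Among the measured compounds shown here, since the one measured example of this exchange, a 1.1-fold higher number from compound 1 to compound 2 (0.03 log units; within the scatter), stayed within the scatter, the step from compound 3 to compound 4 is expected to be similarly small, a 1.1-fold higher number from compound 3 to compound 4 (0.03 log units; within the scatter). Compound 4 is therefore estimated to give 40000 nM in this assay, with a plausible range from 18000 nM to 90000 nM.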

Compound 4, concentration for 50% growth inhibition: 50000 nM
The estimate for compound 4 lay 1.3-fold (0.10 log units) below the measured number, within the range that was stated.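

In this assay, putting chloro in place of bromo gave a 1.4-fold higher number from compound 3 to compound 4 (0.13 log units; within the scatter), so on this second core, too, the exchange left growth inhibition essentially unchanged. Set side by side, the two examples agree, even though the halogen sits at a different place on each core: the same change on two cores in this assay, a 1.1-fold higher number (0.03 log units; within the scatter) from compound 1 to compound 2 and a 1.4-fold higher number (0.13 log units; within the scatter) from compound 3 to compound 4, 1.3-fold (0.10 log units) apart, within the scatter of two such steps This suggests that, between these two cores, the effect of the exchange carries over, and that a result for one halogen on either core is a fair guide to the other halogen on that core, but two pairs are too few to make a general rule for the series, and they show neither why the exchange changes so little nor whether the same would hold on a further core.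

Going by these compounds, all four compounds carry either bromo or chloro on the aromatic ring, so what a fluoro group, a methoxy group or an amine would do at these places remains open. The methyl ester is also common to all four, which leaves open how a carboxylic acid or an amide in its place would affect growth inhibition in this assay.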